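Swapping hydroxy for ethylamino in compound 2

The compounds below may be only part of what the source reports. "The series", "measured", "known", "first", "only" and "open" are said of these compounds alone.

In a functional assay on A2780 cells (Homo sapiens) for antiproliferative activity, read by MTT assay, with a stated time of 48 h (a lower number here means a stronger inhibitor, a higher number a weaker inhibitor), compound 2 `C=C(c1ccc2c(c1)C=CC(C)(C)O2)c1ccc(OC)cc1NC(=O)CO` gives 110 nM and cannot be told apart from compound 1 `COc1ccc(C(=O)c2cc(OC)c(OC)c(OC)c2)c(NC(=O)CO)c1` (100 nM) because the two values lie within the usual scatter. Compound 3 `C=C(c1ccc(OC)cc1NC(=O)CN)c1ccc(OC)c2c1C=CC(C)(C)O2` gives 400 nM and is a weaker inhibitor than compound 2, with a gap beyond the scatter.

Compound 4 `C=C(c1ccc2c(c1)C=CC(C)(C)O2)c1ccc(OC)cc1NC(=O)CNCC` has not yet been measured. Compared with compound 2, compound 4 carries ethylamino in place of hydroxy on a saturated chain carbon bound to a carbonyl carbon.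

Going by the values given here, no measured pair isolates this change, so any expectation here is loose. Among the compounds with values here, the only hint comes from compound 3, the one measured compound with an amino group on that chain carbon, whose value of 400 nM sits on the weaker side. The expected change is a 2.7-fold higher number from compound 2 to compound 4 (0.44 log units; beyond the scatter) and would point toward weaker inhibition, probably just beyond the scatter. For compound 4 the estimated value is 300 nM (expected range 90 nM to 1000 nM).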

Compound 4, half-maximal inhibitory concentration: 1870 nM
For compound 4 the middle estimate is 6.2-fold (0.79 log units) below the measured one; measured number above the stated range.
By their numbers in this assay, from the lowest: compounds 1 and 2 (each within the scatter of the next); then compound 3; then compound 4.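

In this assay, going by these compounds alone, putting ethylamino in place of hydroxy on a saturated chain carbon bound to a carbonyl carbon gives a 17-fold higher number from compound 2 to compound 4 (1.23 log units; beyond the scatter), the first reading of a single change at this position. The result shows that this place is sensitive to what it carries: a large step appears even though the group that leaves and the group that enters each count one hydrogen-bond donor and one hydrogen-bond acceptor, so those counts alone do not set the number here. The data shown offer no measurement that explains the step.

From the compounds shown here alone, it remains open whether the step follows the change from oxygen to nitrogen or the added ethyl chain. Ethoxy, which keeps the ethyl chain on oxygen, and methylamino, which shortens the chain on nitrogen, would help separate the two at this position.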